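Removing the pyrazole methyl: expected stability of compound 4

A few compounds are considered here, and "the series" means these few. Any claim that something is new, unique, unknown or untested is made for them only; others in the source may bear on it.

The measured compounds and their values:
Compound 1, `Cc1[nH]ncc1-c1ccc2nc(C3COc4ccccc4C3)oc2c1`: 1.17 h
Compound 2, `Cc1ccc2c(c1)CC(c1nc3ccc(-c4ccnc(N)n4)cc3o1)CO2`: 0.417 h
Compound 3, `Cc1[nH]ncc1-c1ccc2nc(C3COc4ccccc4C3)[nH]c2c1`: 0.5 h

In an in vitro ADME assay on microsomes from liver (Homo sapiens) for metabolic stability (on this read-out higher numbers stand for a longer-lived compound and lower numbers for a shorter-lived compound), compound 1 gives 1.17 h, and compound 3 gives 0.5 h, a gap beyond the scatter, so compound 3 sits below compound 1. Compound 3 and compound 2 lie within the scatter of each other. Compound 4, `c1ccc2c(c1)CC(c1nc3ccc(-c4cn[nH]c4)cc3[nH]1)CO2`, has not yet been measured in this assay. It differs from compound 3 by hydrogen in place of methyl on an aromatic carbon. For the measured compounds named here, no measured pair shows this change, so the size of its effect on this assay is unknown. Compound 4 is therefore expected to stay close to compound 3, with an estimated step of a 1.1-fold lower number from compound 3 to compound 4 (0.05 log units; within the scatter), none beyond the scatter. The estimate for compound 4 is 0.45 h, between 0.2 h and 1 h.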

Compound 4, half-life: 0.333 h
Beside the measured number, compound 4's estimate is 1.4-fold (0.13 log units) above it, and the stated range covers the measured number.
By their numbers in this assay, from the lowest: compounds 4, 2 and 3 (each within the scatter of the next); then compound 1.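

For the compounds shown here, the pair gives the first reading of this change: in this assay, going from 5-methyl-1H-pyrazol-4-yl to 1H-pyrazol-4-yl gives a 1.5-fold lower number from compound 3 to compound 4 (0.18 log units; within the scatter) and so stays within the scatter. On this single pair, the methyl on this aromatic carbon can be replaced by hydrogen with no shift beyond the scatter. No measured evidence bears on why the step is this size. The compounds shown leave open how an amine or an ethyl group at this place would read. They also leave open whether the same change gives a similar step on the core of compound 1.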